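Methoxy for chloro on a second indole scaffold

A few compounds are considered here, and "the series" means these few. Any claim that something is new, unique, unknown or untested is made for them only; others in the source may bear on it.

Measured compounds:
compound 1 `CC1=NNC(=O)C1C(c1c(-c2ccccc2)[nH]c2ccc(Cl)cc12)c1c(-c2ccccc2)[nH]c2ccc(Cl)cc12`, 7000 nM
compound 2 `COc1ccc2[nH]c(-c3ccccc3)c(C(c3c(-c4ccccc4)[nH]c4ccc(Cl)cc34)C3C(=O)NN=C3C)c2c1`, 1100 nM
compound 3 `CC1=NNC(=O)C1C(c1c[nH]c2ccccc12)c1c(-c2ccccc2)[nH]c2ccc(Cl)cc12`, 1600 nM

The three compounds were tested in a functional assay on A549 cells (Homo sapiens) for cytotoxicity, read by MTT assay; a lower number here means a stronger inhibitor, a higher number a weaker inhibitor. Compound 1 gives 7000 nM, while compound 2 gives 1100 nM; the step of a 6.4-fold lower number from compound 1 to compound 2 (0.80 log units; beyond the scatter) is the change (methoxy in place of chloro on an aromatic carbon). Compound 3 gives 1600 nM. The difference between the core of compound 3 and the core of compound 1 is not broken down here.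

The unmeasured compound 4 `COc1ccc2[nH]c(-c3ccccc3)c(C(c3c[nH]c4ccccc34)C3C(=O)NN=C3C)c2c1` arises from compound 3 by methoxy in place of chloro on an aromatic carbon, the same change as from compound 1 to compound 2 at the same place. The earlier step of a 6.4-fold lower number from compound 1 to compound 2 (0.80 log units; beyond the scatter) was made on a core that differs from that of compound 3, so compound 4 is expected to move in the same direction but the size is less certain. The expected step is a 3.2-fold lower number from compound 3 to compound 4 (0.51 log units; beyond the scatter), resting on the step of a 6.4-fold lower number from compound 1 to compound 2 (0.80 log units; beyond the scatter) and on the value of compound 3, 1600 nM. Compound 4 is therefore estimated at 500 nM, between 150 nM and 2000 nM.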

Compound 4, half-maximal inhibitory concentration: 2700 nM
Compound 4: the middle estimate sits 5.4-fold (0.73 log units) below what was measured; measured number above the stated range.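

In this assay, methoxy in place of chloro on the second core gives a 1.7-fold higher number from compound 3 to compound 4 (0.23 log units; within the scatter), so compound 3 and compound 4 cannot be told apart on this measure. Set beside the earlier step, the change does not carry over in size from one core to the other: the same change on two cores in this assay, a 6.4-fold lower number (0.80 log units; beyond the scatter) from compound 1 to compound 2 and a 1.7-fold higher number (0.23 log units; within the scatter) from compound 3 to compound 4, 11-fold (1.03 log units) apart, beyond the scatter of two such steps. Among the compounds shown, the clear drop in the number is therefore confined to the pair on the core of compound 1, but with a single pair on each core this does not show which feature of the cores separates the two results, or how the change would behave on any further core.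

The compounds shown leave open whether other groups on the same aromatic carbon, such as an amine, a hydroxy or a fluoro, would also give different results on the two cores. They also leave open whether a longer chain such as ethoxy in place of methoxy would follow either pair.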